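Two Carboxylic Acids on the Amide Nitrogen of Compound 1

A few compounds are considered here, and "the series" means these few. Any claim that something is new, unique, unknown or untested is made for them only; others in the source may bear on it.

Compound 1 `CCn1c(C(=O)NCCNC(=O)OC(C)(C)C)ccc1C(CC)(CC)c1ccc(OCS(=O)(=O)c2ccccc2)c(C)c1` carries a 2-((tert-butoxycarbonyl)amino)ethyl group on an amide-type nitrogen. In a functional assay on BXPC-3 cells (Homo sapiens) for antiproliferative activity, read by MTT assay, with a stated time of 24 h (on this read-out higher numbers stand for weaker inhibition and lower numbers for stronger inhibition), compound 1 gives only a limit, > 50000 nM, so it stands at the limit of > 50000 nM in this assay, at which 1 of the 3 values shown sits, rather than at a number. Compound 2 `CCn1c(C(=O)NC2(CO)CC2)ccc1C(CC)(CC)c1ccc(OCS(=O)(=O)c2ccccc2)c(C)c1` gives 45400 nM, and compound 3 `CCn1c(C(=O)N[C@H](C(=O)O)C(C)C)ccc1C(CC)(CC)c1ccc(OCS(=O)(=O)c2ccccc2)c(C)c1` gives 16200 nM. The steps of an at least 3.0-fold lower number from compound 1 to compound 3 (0.48 log units; beyond the scatter) and a 2.8-fold lower number from compound 2 to compound 3 (0.45 log units; beyond the scatter) lie beyond the scatter, whereas an at least 1.1-fold lower number from compound 1 to compound 2 (0.04 log units; that floor lies within the scatter) does not. Compound 4 `CCn1c(C(=O)N[C@H](CC(=O)O)C(=O)O)ccc1C(CC)(CC)c1ccc(OCS(=O)(=O)c2ccccc2)c(C)c1` differs from compound 1 by 1,2-dicarboxyethyl in place of 2-((tert-butoxycarbonyl)amino)ethyl on an amide-type nitrogen. Because of an at least 3.0-fold lower number from compound 1 to compound 3 (0.48 log units; beyond the scatter) a lower number is expected here as well. For compound 4 the expected change is an at least 4.1-fold lower number from compound 1 to compound 4 (0.61 log units; beyond the scatter). Compound 4 is estimated at 12000 nM, with a likely range from 4000 nM to 40000 nM.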

Compound 4, half-maximal inhibitory concentration: > 50000 nM
Compound 4 gave a limit, no number; the forecaster's own chance of this, stated with the estimate: 15%; middle value at least 4.1-fold (0.61 log units) away from the limit.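

Swapping 1-carboxy-2-methylpropyl for 1,2-dicarboxyethyl on the amide-type nitrogen gives an at least 3.0-fold higher number from compound 3 to compound 4 (0.48 log units; beyond the scatter), so a carboxylic acid in this group does not by itself bring a lower number. The change from 1-(hydroxymethyl)cyclopropyl gives an at least 1.1-fold higher number from compound 2 to compound 4 (0.04 log units; that floor lies within the scatter), and the step from compound 1 to compound 4 cannot be read, as both values are limits. Compound 4 gives a limit, not a number: the limit of > 50000 nM in this assay, at which 2 of the 4 values shown sit.

As far as these compounds go, it stays open whether the second carboxylic acid or the loss of the 2-methylpropyl part sets compound 4 apart from compound 3. From the compounds shown here alone, how a primary amine or a longer chain ending in one carboxylic acid would read on this nitrogen is also open.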